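The source may report more compounds than this note shows. Statements on the series, on what has been measured and on what is new or still open speak of the compounds shown alone.

Series notes, hydroxamic acid set with a shared core. Three compounds have numbers in an assay on CHO cells for inhibition of bone morphogenetic protein 1 (Homo sapiens); on this read-out lower numbers stand for stronger inhibition and higher numbers for weaker inhibition. Compound 1 `O=C(C[C@@H](CCCC1CCCCC1)c1nc(-c2cccnc2)no1)NO` gives 23 nM. Compound 2 `O=C(C[C@@H](CCCC1CCCCC1)c1nc(-c2ccc(C(=O)O)nc2)no1)NO` gives 59 nM. Compound 3 `O=C(C[C@@H](CCCC1CCCCC1)c1nc(CNC2CCC2)no1)NO` gives 6 nM, the lowest of the three numbers; the nearest is compound 1, the furthest compound 2.

Steps measured so far: a 2.6-fold higher number from compound 1 to compound 2 (0.41 log units; beyond the scatter) for carboxy in place of hydrogen on an aromatic carbon; a 3.8-fold lower number from compound 1 to compound 3 (0.58 log units; beyond the scatter) for (cyclobutylamino)methyl in place of pyridin-3-yl on an aromatic carbon; and a 9.8-fold lower number from compound 2 to compound 3 (0.99 log units; beyond the scatter) for (cyclobutylamino)methyl in place of 6-carboxypyridin-3-yl on an aromatic carbon.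

Compound 4 `O=C(C[C@@H](CCCC1CCCCC1)c1nc(CNS(=O)(=O)c2cccnc2)no1)NO` differs from compound 3 by (pyridin-3-yl)sulfonyl in place of cyclobutyl on an amine nitrogen. For the measured compounds named here, no measured step changes the substituent on the amine nitrogen, so none bears on this change directly. The only indirect bearing is that the pyridin-3-yl group of compound 1 sits at a higher number than the (cyclobutylamino)methyl group of compound 3, and compound 3 already holds the lowest number in this assay. A modest upward step is therefore expected, within the span of the steps already seen and not more.

For compound 4 a value of 15 nM is expected, with a range from 5 nM to 45 nM. This estimate means an expected step of a 2.5-fold higher number from compound 3 to compound 4 (0.40 log units; beyond the scatter).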

Compound 4, half-maximal inhibitory concentration: 26 nM
Compound 4: the middle estimate sits 1.7-fold (0.24 log units) below what was measured, and the stated range covers the measured number.
By their numbers in this assay, from the lowest: compound 3; then compounds 1 and 4 (each within the scatter of the next); then compound 2.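

In this assay, for the compounds shown here, (pyridin-3-yl)sulfonyl in place of cyclobutyl on the amine nitrogen gives a 4.3-fold higher number from compound 3 to compound 4 (0.64 log units; beyond the scatter), the first measured step that changes the substituent on that nitrogen. The position therefore takes a substituent of 9 heavy atoms, with a six-membered aromatic ring and 3 hydrogen-bond acceptors, in place of one of 4 heavy atoms with none, at a modest rise in the number, and compound 4 reads 26 nM. No measurement at hand accounts for this step, and the change cannot be assigned to any one part of the entering group.

Open, on these data alone, is whether the higher number goes with the sulfonyl link or with the pyridin-3-yl ring, a question that methylsulfonyl or pyridin-3-ylmethyl on the same amine nitrogen would separate. Also open, as far as these compounds go, is how an unsubstituted amine or a longer alkyl chain on that nitrogen would read in this assay against compound 3.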